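Amide nitrogen substituents on a shared core: cytotoxicity notes

The source may report more compounds than this note shows. Statements on the series, on what has been measured and on what is new or still open speak of the compounds shown alone.

Measured so far:
compound 1, `CCNC(=O)Cn1nc(N)c2c(C(F)(F)F)cc(-c3ccccc3)nc21`: in a functional assay on A549 cells (Homo sapiens) for cytotoxicity, read by MTT assay, with a stated time of 24 h (on this read-out higher numbers stand for weaker inhibition and lower numbers for stronger inhibition), compound 1 gives 18800 nM
compound 2, `NNC(=O)Cn1nc(N)c2c(C(F)(F)F)cc(-c3ccccc3)nc21`: in this assay compound 2 gives 53600 nM

Within the data shown here, compound 2 holds the higher of the two numbers, its nearest neighbour being compound 1, and the single step measured on this core, a 2.9-fold higher number from compound 1 to compound 2 (0.46 log units; beyond the scatter), is the one that bears on the next change. Compound 3, `Nc1nn(CC(=O)NCCO)c2nc(-c3ccccc3)cc(C(F)(F)F)c12`, differs from compound 2 by 2-hydroxyethyl in place of amino on an amide-type nitrogen. The step from compound 1 to compound 2 shows that replacing ethyl with amino at this position raised the number; the 2-hydroxyethyl group restores a two-carbon chain on the amide-type nitrogen and keeps a hydrogen-bond donor, so the number is expected to fall back toward that of compound 1 rather than rise further. Compound 3 is therefore estimated at 22000 nM (range 9000 nM to 55000 nM), which is expected to mean a 2.4-fold lower number from compound 2 to compound 3 (0.39 log units; beyond the scatter).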

Compound 3, half-maximal inhibitory concentration: 128000 nM
Compound 3: middle estimate off by 5.8-fold (0.76 log units), on the low side; measured number above the stated range.
By their numbers in this assay, from the lowest: compound 1; then compound 2; then compound 3.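

In this assay, the change to 2-hydroxyethyl gives a 2.4-fold higher number from compound 2 to compound 3 (0.38 log units; beyond the scatter) and moves the number further up, not back toward the ethyl amide. Hydroxy in place of hydrogen on a saturated chain carbon, two bonds along the chain from an amide-type nitrogen, gives a 6.8-fold higher number from compound 1 to compound 3 (0.83 log units; beyond the scatter) as the largest step in the set, so a two-carbon chain on this nitrogen does not by itself keep the number low: compound 1 and compound 3 both carry one, and the chain end separates them. Nothing available explains this rise.

On these data alone, it remains open whether the higher number is specific to the terminal hydroxy or would also appear with a methoxy, an amine or a carboxylic acid at the chain end. A longer chain, such as 3-hydroxypropyl, also remains to be placed against compound 1 and compound 3.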